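The source may report more compounds than this note shows. Statements on the series, on what has been measured and on what is new or still open speak of the compounds shown alone.

Measured compounds in a functional assay on MDA-MB-453 cells (Homo sapiens) for antiproliferative activity, read by MTT assay, with a stated time of 72 h; a lower number here means a stronger inhibitor, a higher number a weaker inhibitor:
Compound 1 `CCOC(=O)c1c[nH]nc1N/C=C1\C(=O)NN=C1c1ccccc1`, compound 1 gives 74600 nM.
Compound 2 `Cc1cc(N/C=C2\C(=O)NN=C2c2ccccc2)n[nH]1`, compound 2 gives 93000 nM.
Compound 3 `O=C1NN=C(c2ccccc2)/C1=C/Nc1cc(-c2ccccc2)[nH]n1`, compound 3 gives 11500 nM.

Compound 2 carries the highest number of the three in this assay. Compound 1 sits within the scatter of compound 2, whereas compound 3 lies beyond it: the change from methyl to phenyl on an aromatic carbon produced an 8.1-fold lower number from compound 2 to compound 3 (0.91 log units; beyond the scatter).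

Compound 4 `CSC[C@H](N/C=C1\C(=O)NN=C1c1ccccc1)C(=O)O` has not yet been measured. Its difference from compound 2 is 1-carboxy-2-(methylsulfanyl)ethyl in place of 5-methyl-1H-pyrazol-3-yl on an amine nitrogen. This change replaces the whole aromatic ring attached to the amine nitrogen with an open chain bearing a carboxylic acid and a methylsulfanyl group, so none of the measured steps bears directly on it; the only step shown concerns a substituent on that ring, which is removed here. Among the measured compounds shown here, the three measured compounds all remain weak, and no measured step points to a gain from removing the ring. The expected step is therefore a 1.1-fold higher number from compound 2 to compound 4 (0.03 log units; within the scatter), that is, no change beyond the scatter. Compound 4 is estimated at 100000 nM, with a range from 30000 nM to 300000 nM.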

Compound 4, half-maximal inhibitory concentration: 105000 nM
For compound 4 the middle estimate is 1.1-fold (0.02 log units) below the measured one; the measured number falls inside the stated range.
By their numbers in this assay, from the lowest: compound 3; then compounds 1, 2 and 4 (each within the scatter of the next).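

In this assay, the open chain 1-carboxy-2-(methylsulfanyl)ethyl in place of 5-methyl-1H-pyrazol-3-yl on the amine nitrogen gives a 1.1-fold higher number from compound 2 to compound 4 (0.05 log units; within the scatter), so at this position, losing the aromatic ring from compound 2 brings no change beyond the scatter. The earlier step altered only a substituent on that ring, whereas this one shows that a chain with no ring can take its place without moving the number beyond the scatter, although both compounds remain weak. Nothing available here bears on why the replacement leaves the number within the scatter.

The compounds shown leave open whether the carboxylic acid or the methylsulfanyl group contributes anything to this result. They also do not show whether a methyl ester in place of the acid, or a phenyl on the chain, would lower the number as the phenyl of compound 3 did on the ring.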